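One Chloro Group Less: Estimating Compound 4

The source may report more compounds than this note shows. Statements on the series, on what has been measured and on what is new or still open speak of the compounds shown alone.

Compound 1 `Cc1ccc2nc(NC(=O)/C=C/c3ccc(Cl)cc3)sc2c1`: 152 umol/kg
Compound 2 `CC(=O)N1N=C(Nc2nc3ccccc3s2)CC1OC1=CC=C1`: 382 umol/kg
Compound 3 `COc1ccc(C2CC(Nc3nc4ccc(Cl)cc4s3)=NN2C(C)=O)cc1`: 93.3 umol/kg

All three measured compounds were tested in a functional assay on the whole organism (Hindlimb, strain albino) with Mus musculus as the target, in the maximal electroshock model, with a stated time of 0.5 h; a higher number here means that more compound is needed for the effect, a lower number that less compound is needed. In this assay compound 1 gives 152 umol/kg, the second highest of the three numbers. Its nearest neighbour is compound 3, whose value of 93.3 umol/kg sits within the usual scatter of compound 1, so the two cannot be told apart on these data. Compound 2, at 382 umol/kg, lies beyond the scatter above compound 1 and so needs more material for the same effect.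

Compound 4 `Cc1ccc2nc(NC(=O)/C=C/c3ccccc3)sc2c1` has not yet been measured. It differs from compound 1 in a single place: hydrogen in place of chloro on an aromatic carbon. Within the data shown here, no pair of measured compounds shows this same change, so its effect in this assay cannot be read off directly; the expectation rests on compound 1 alone. A modest rise in the number, at or just beyond the edge of the scatter, is expected, though a result indistinguishable from compound 1 would not be surprising. The expected step of a 1.4-fold higher number from compound 1 to compound 4 (0.16 log units; within the scatter) is therefore small and upward. Compound 4 is estimated at 220 umol/kg, with a range from 100 umol/kg to 450 umol/kg.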

Compound 4, dose for half-maximal effect: 380 umol/kg
The estimate for compound 4 lay 1.7-fold (0.24 log units) below the measured number, within the range that was stated.
By their numbers in this assay, from the lowest: compounds 3 and 1 (each within the scatter of the next); then compounds 4 and 2 (each within the scatter of the next).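

Replacing the chloro group with hydrogen on the six-membered aromatic ring, para to a large group, gives a 2.5-fold higher number from compound 1 to compound 4 (0.40 log units; beyond the scatter) in this assay. Among these compounds, this is the only direct reading of the change at this position, since compounds 1, 2 and 3 differ from one another in more than one place and could not isolate what the chloro group contributes. The pair shows that, on this core, the change from 4-chlorophenyl to phenyl is large enough to stand out from the scatter, with more compound needed for the same effect once the chloro group is gone, although no measurement shown here accounts for the rise.

As far as these compounds go, it remains open whether chloro is unusual at this position or whether another group there, such as fluoro, an amine or a carboxylic acid, would give a number closer to that of compound 1 or even lower. With a single pair on a single core, it is also unknown whether the same change would give a similar step at another position on the ring or on a different core.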